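Moving a hydroxyl changes cytotoxicity on a shared core

The compounds below may be only part of what the source reports. "The series", "measured", "known", "first", "only" and "open" are said of these compounds alone.

Measured compounds:
Compound 1 `Oc1ccc(-c2cc(-c3cccs3)cc(-c3ccccc3O)n2)cc1` — > 50000 nM
Compound 2 `Oc1ccc(-c2cc(-c3cccs3)cc(-c3cccc(O)c3)n2)cc1` — 4140 nM
Compound 3 `Oc1cccc(-c2cc(-c3ccsc3)cc(-c3ccccc3O)n2)c1` — > 50000 nM

In a functional assay on HeLa cells (Homo sapiens) for cytotoxicity, read by CCK-8 assay (a lower number here means a stronger inhibitor, a higher number a weaker inhibitor), compound 1 reaches only the limit > 50000 nM. Compound 2 gives 4140 nM in this assay. The change 3-hydroxyphenyl in place of 2-hydroxyphenyl on an aromatic carbon thus produced an at least 12-fold lower number from compound 1 to compound 2 (1.08 log units; beyond the scatter). Compound 3 also sits at a limit, > 50000 nM, in this assay. How the core of compound 3 differs from the core of compound 1 is not broken down here. Compound 4 `Oc1cccc(-c2cc(-c3ccsc3)cc(-c3cccc(O)c3)n2)c1` differs from compound 3 by 3-hydroxyphenyl in place of 2-hydroxyphenyl on an aromatic carbon, the same kind of change as before, though the surroundings differ: in compound 1 the place was meta to a 4-hydroxyphenyl group and meta to a thiophen-2-yl group, whereas here it is meta to a 3-hydroxyphenyl group and meta to a thiophen-3-yl group. From the compounds shown here alone, because of the limit of > 50000 nM in this assay, at which 2 of the 3 values shown sit, the true starting point of compound 3 is unknown, so the size of the step to compound 4 is expected only loosely as an at least 6.2-fold lower number from compound 3 to compound 4 (0.79 log units; beyond the scatter). Compound 4 is estimated at 8000 nM, between 2000 nM and 50000 nM.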

Compound 4, half-maximal inhibitory concentration: 16600 nM
Estimate against measurement, compound 4: 2.1-fold (0.32 log units) below; measured number inside the range.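

In this assay, placing 3-hydroxyphenyl where 2-hydroxyphenyl stood on the second core again lowers the number, with an at least 3.0-fold lower number from compound 3 to compound 4 (0.47 log units; beyond the scatter). The direction of the change therefore carries from one core to the other, but its size cannot be compared between them: the same change on two cores in this assay, an at least 12-fold lower number (1.08 log units; beyond the scatter) from compound 1 to compound 2 and an at least 3.0-fold lower number (0.47 log units; beyond the scatter) from compound 3 to compound 4; the limit leaves it open whether they differ The values of compound 1 and compound 3 are limits and not numbers, so neither step has an exact size: the limit of > 50000 nM in this assay, at which 2 of the 4 values shown sit.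

The compounds shown leave open how a 3-aminophenyl or 3-methoxyphenyl group would read at this place in this assay. From the compounds shown here alone, the separate contributions of the thiophen-2-yl and thiophen-3-yl groups to the values also remain open.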